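Benzyl chloride purine series: amino for chloro on the core

This account rests on a few compounds, and the source may have more. Where it says the series, first, only, none or still open, it means among the compounds named here.

Measured so far:
compound 1, `ClCc1ccc(Cn2cnc3c(Cl)ncnc32)cc1`: 4780 nM
compound 2, `ClCc1cccc(Cn2cnc3c(Cl)nc(Cl)nc32)c1`: 3380 nM
compound 3, `ClCc1cccc(Cn2cnc3nc(Cl)nc(Cl)c32)c1`: 1040 nM

All three numbers come from a functional assay on MOLT-4 cells (Homo sapiens) for cytotoxicity, read by sulforhodamine B assay, with a stated time of 48 h; on this read-out higher numbers stand for weaker inhibition of growth and lower numbers for stronger inhibition of growth. Compound 2 holds the second highest of the three numbers. Its nearest neighbour is compound 1, which gives 4780 nM, a gap that lies within the usual scatter; the two are not to be ordered against each other. The furthest is compound 3, which gives 1040 nM, a gap beyond the scatter, so compound 3 stands as the stronger inhibitor of growth of the pair.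

The next compound, compound 4, `Nc1nc(Cl)c2ncn(Cc3cccc(CCl)c3)c2n1`, differs from compound 2 in one place: amino in place of chloro on an aromatic carbon. Going by the values given here, no pair among the measured compounds shows this kind of change, so no measured step can anchor the expectation. The benzyl chloride part, shared by all four compounds, is kept in compound 4 unchanged.

For compound 4 a step toward weaker inhibition of growth in this assay is expected, around the edge of the scatter, shown as a 1.6-fold higher number from compound 2 to compound 4 (0.21 log units; within the scatter). Compound 4 is thus estimated at 5500 nM, with a range from 1800 nM to 17000 nM.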

Compound 4, concentration for 50% growth inhibition: 4780 nM
The estimate for compound 4 lay 1.2-fold (0.06 log units) above the measured number; measured number inside the range.
By their numbers in this assay, from the lowest: compound 3; then compounds 2, 1 and 4 (each within the scatter of the next).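

In this assay, going by these compounds alone, the one comparison that differs in a single place gives a 1.4-fold higher number from compound 2 to compound 4 (0.15 log units; within the scatter), so amino in place of chloro on this aromatic carbon, between two ring nitrogen atoms, produces no difference that can be read. At this position, a group counted with one hydrogen-bond donor and one hydrogen-bond acceptor therefore stands in for one counted with neither, with the benzyl chloride part and the remaining chloro group unchanged, and growth inhibition of these cells is not separated between the two compounds. Nothing at hand ties this outcome to any property of either group.

Still open, from the compounds shown here alone, is whether this holds only for amino or extends to larger or differently built groups at the same carbon, such as methylamino, dimethylamino, methoxy or hydroxyl. Also open, going by these compounds, is whether amino in place of chloro gives a comparable result on the core of compound 3, and how much the chloromethyl group contributes, which a hydroxymethyl or plain methyl group in its place on compound 4 would address.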